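Adding decyl to a compound stuck at the limit

The source may report more compounds than this note shows. Statements on the series, on what has been measured and on what is new or still open speak of the compounds shown alone.

In a functional assay on PC-3 cells (Homo sapiens) for inhibition, read by MTT assay, with stated times of 18 h and 4 h (a lower number here means a stronger inhibitor, a higher number a weaker inhibitor), compound 3 (`CCCCCCOP(=O)(O)OCCSC(=S)N1CCCC1`) gives > 100000 nM, which is a limit of the assay and not a number. Compound 2 (`CCCCCCCCCCOP(=O)(O)OCCSC(=S)N1CCCC1`) gives 56100 nM, a real reading from a compound with a longer chain. Compound 4 (`CCCCCCCCCCCCCCCCOP(=O)(O)OCCSC(=S)N1CCCC1`) is still unmeasured and differs from compound 3 by a single change: decyl in place of hydrogen on a saturated chain carbon, six bonds along the chain from an oxygen on an unsaturated carbon. Decyl replaces hydrogen on a saturated chain carbon, six bonds along the chain from an oxygen on an unsaturated carbon.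

For the measured compounds named here, one measured step bears on this: an at least 1.7-fold higher number from compound 2 to compound 3 (0.25 log units; that floor lies within the scatter). It removes butyl at that same place, so it runs the opposite way, and as a floor it offers only weak guidance. The chain of compound 4 also appears on a different core in compound 1 (`CCCCCCCCCCCCCCCCOP(=O)(O)OCCSC(=S)N1CCCCCC1`), and compound 1 gives 32100 nM, the best available guide to the level. A move to a lower number in this assay is therefore expected, with an estimated at least 2.8-fold lower number from compound 3 to compound 4 (0.45 log units; beyond the scatter). For compound 4 the expected value is 35000 nM, with an estimated range from 14000 nM to 80000 nM.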

Compound 4, half-maximal inhibitory concentration: 65700 nM
Compound 4: the middle estimate sits 1.9-fold (0.27 log units) below what was measured; low and high end bracket the measured number.
By their numbers in this assay, from the lowest: compounds 1, 2 and 4 (each within the scatter of the next, the first and the last beyond it). At a limit, above all of these: compound 3.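

The change from hydrogen to decyl at this place gives, in this assay, an at least 1.5-fold lower number from compound 3 to compound 4 (0.18 log units; that floor lies within the scatter), so the gain over the shortest chain can be read only as a floor. Compound 3 stands at a limit of the assay: the limit of > 100000 nM in this assay, at which 1 of the 4 values shown sits.

Extending the chain further brings no readable gain, with a 1.2-fold higher number from compound 2 to compound 4 (0.07 log units; within the scatter), while the first comparison with the chain held fixed shows a modest effect at the other end of the molecule, with pyrrolidin-1-yl in place of azepan-1-yl on a thiocarbonyl carbon giving a 2.0-fold higher number from compound 1 to compound 4 (0.31 log units; beyond the scatter).

Still open, from the compounds shown here alone, is whether an amine at the far end of the chain, or a longer chain, would move the number at all. Also open, going by these compounds, is whether the difference between compound 1 and compound 4 would hold with a shorter chain, or with a morpholin-4-yl group on the thiocarbonyl carbon.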